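The compounds below may be only part of what the source reports. "The series", "measured", "known", "first", "only" and "open" are said of these compounds alone.

Measured so far:
Compound 1, `Cc1cc(-c2ccc(Cl)cc2Cl)c(S(C)(=O)=O)cc1C(=O)N=C(N)N`, gives 42 nM in a functional assay for inhibition of sodium/hydrogen exchanger (Oryctolagus cuniculus); a lower number here means a stronger inhibitor, a higher number a weaker inhibitor.
Compound 2, `Cc1cc(N2CCCCC2)c(S(C)(=O)=O)cc1C(=O)N=C(N)N`, gives 21 nM in this assay.

Within the data shown here, compound 2 stands lowest of the two numbers, but its only neighbour is compound 1, and the step from compound 1 to compound 2 is a 2.0-fold lower number from compound 1 to compound 2 (0.30 log units; within the scatter), so the two cannot be told apart on these data. The next compound is compound 3, `Cc1ccc(S(C)(=O)=O)cc1C(=O)N=C(N)N`. It differs from compound 2 in one place: hydrogen in place of piperidin-1-yl on an aromatic carbon. Among the measured compounds shown here, only one measured step exists, the one from compound 1 to compound 2, and it swaps one group of similar size for another on the same aromatic carbon; it says little about taking the group away altogether, which is what happens here. Without a guide of that kind, losing a group of this size more often weakens than strengthens a compound in this assay, so a step upward in the number is expected, a 4.8-fold higher number from compound 2 to compound 3 (0.68 log units; beyond the scatter), with wide uncertainty. Compound 3 is therefore estimated at 100 nM, within a range of 30 nM to 400 nM.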

Compound 3, half-maximal inhibitory concentration: 150 nM
Estimate against measurement, compound 3: 1.5-fold (0.18 log units) below, within the range that was stated.
By their numbers in this assay, from the lowest: compounds 2 and 1 (each within the scatter of the next); then compound 3.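

Taking the group away and leaving only hydrogen on this aromatic carbon gives, in this assay, a 7.1-fold higher number from compound 2 to compound 3 (0.85 log units; beyond the scatter), and a 3.6-fold higher number from compound 1 to compound 3 (0.55 log units; beyond the scatter), and both steps lie beyond the scatter. The earlier pair showed only that piperidin-1-yl and 2,4-dichlorophenyl could not be told apart, whereas these steps show that what sits at this place does change the number: two quite different groups, one a non-aromatic ring with a hetero atom and the other a chlorinated aromatic ring, each give a lower number than bare hydrogen. Nothing measured here explains this difference, so the data record the effect of the change but not the reason for it.

The compounds shown leave open how much of a group this place needs, since nothing lies between hydrogen and these two ring groups; a single methyl, a chlorine atom or a simple open-chain amine such as dimethylamino would fill that gap. They also leave open whether the nitrogen of piperidin-1-yl matters, which a cyclohexyl ring, made of carbon only, could test.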